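Swapping Hydroxy for Dimethylamino on the Unbrominated Core

A few compounds are considered here, and "the series" means these few. Any claim that something is new, unique, unknown or untested is made for them only; others in the source may bear on it.

Compound 1 `Cc1nc2ccc(Br)cc2c(=O)n1NCc1nnc(N2C(=O)CSC2c2ccc(O)cc2)s1` gives 60% in a functional assay on the whole organism (strain albino) with Rattus norvegicus as the target, in the maximal electroshock model, with a stated time of 1 h, at a dose of 30 mg/kg by the intraperitoneal route; a higher number here means more inhibition at the dose given (going by the name of the read-out), a lower number less inhibition. Compound 2 `Cc1nc2ccc(Br)cc2c(=O)n1NCc1nnc(N2C(=O)CSC2c2ccc(N(C)C)cc2)s1` gives 60% in this assay, and the step of no change at the digits printed from compound 1 to compound 2 (within the scatter). Compound 3 `Cc1nc2ccccc2c(=O)n1NCc1nnc(N2C(=O)CSC2c2ccc(O)cc2)s1` gives 60% in this assay, with no change at the digits printed from compound 1 to compound 3 (within the scatter). Compound 3 thus stands level with compounds 1 and 2 at the digits shown; its nearest neighbour is compound 1 and its furthest compound 2, and neither gap reaches beyond the scatter.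

Compound 4 `Cc1nc2ccccc2c(=O)n1NCc1nnc(N2C(=O)CSC2c2ccc(N(C)C)cc2)s1` has not yet been measured in this assay. It differs from compound 3 as follows: dimethylamino in place of hydroxy on an aromatic carbon. Going by the values given here, one measured step bears directly on this change, no change at the digits printed from compound 1 to compound 2 (within the scatter), where the same replacement, dimethylamino in place of hydroxy on an aromatic carbon, was made on a core carrying bromo and produced nothing beyond the scatter. In addition, no change at the digits printed from compound 1 to compound 3 (within the scatter) shows that the presence or absence of bromo itself made no difference to the read-out. With both steps flat, the expectation for compound 4 is a step of no change at the digits printed from compound 3 to compound 4 (within the scatter), that is, no movement beyond the scatter in either direction. The estimate for compound 4 is therefore 60%, with a range from 45% to 75%.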

Compound 4, a percentage reported as inhibition, in the whole organism at one dose (the size of the read-out at that dose, not a potency): 60%
Estimate against measurement, compound 4: no gap at the digits printed; low and high end bracket the measured number.
By their numbers in this assay, from the lowest: compounds 1, 2, 3 and 4 (each within the scatter of the next).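

On the core without bromo, the step from 4-hydroxyphenyl to 4-(dimethylamino)phenyl in this assay reads no change at the digits printed from compound 3 to compound 4 (within the scatter), so this change has now been read on two cores and comes out alike on both: the same change on two cores in this assay, no change at the digits printed (within the scatter) from compound 1 to compound 2 and no change at the digits printed (within the scatter) from compound 3 to compound 4, 0 percentage points apart, within the scatter of two such steps

The bromo position, earlier read only with hydroxy on the aromatic ring, can now also be read with dimethylamino in place, where hydrogen in place of bromo gives no change at the digits printed from compound 2 to compound 4 (within the scatter), and again the two cores agree: the same change on two cores in this assay, no change at the digits printed (within the scatter) from compound 1 to compound 3 and no change at the digits printed (within the scatter) from compound 2 to compound 4, 0 percentage points apart, within the scatter of two such steps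

Taken together, the four compounds show that neither change moves the read-out beyond the scatter, whichever group stands at the other place, and that a hydroxy with its hydrogen-bond donor can give way to a dimethylamino without one and leave the read-out level at this dose.

All four compounds stand level at a single dose and a single time, so these values cannot tell whether they would separate at a lower dose or at another time. From the compounds shown here alone, it also remains open whether a carboxylic acid or a methoxy on the same aromatic carbon, or chloro in place of bromo, would keep the read-out level in this assay.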